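Swapping the chlorophenyl group of compound 2

The source may hold more compounds than are shown below. What is called first, only, known or untested is meant among the compounds shown, and "the series" means these compounds.

In an in vitro ADME assay on microsomes from liver (Homo sapiens) for metabolic stability (a lower number here means slower removal, a higher number faster removal of the compound), compound 2 (`O=C(COCc1ccccc1)N1CCN(c2ccc(Cl)cc2)CC1`) gives 290 mL.min-1.g-1 and so sits within the scatter of compound 1 (`O=C(COCc1ccccc1)N1CCN(c2ccccc2Cl)CC1`) at 540 mL.min-1.g-1 and of compound 3 (`O=C(COCc1ccccc1)N1CCN(c2ccc(F)cc2F)CC1`) at 580 mL.min-1.g-1 as well. Compound 4 (`O=C(COCc1ccccc1)N1CCN(c2ccc(F)cc2Cl)CC1`) is still unmeasured and has 2-chloro-4-fluorophenyl in place of 4-chlorophenyl on an amine nitrogen in a ring. Two measured steps lead to compound 2: a 1.9-fold lower number from compound 1 to compound 2 (0.27 log units; within the scatter) and a 2.0-fold higher number from compound 2 to compound 3 (0.30 log units; within the scatter) and neither goes beyond the scatter. The groups of compound 1 and compound 3 resemble the new one most, and only a 1.1-fold higher number from compound 1 to compound 3 (0.03 log units; within the scatter) separates them. The expected change is a 1.7-fold higher number from compound 2 to compound 4 (0.22 log units; within the scatter) and stays inside the scatter. For compound 4 the estimated value is 480 mL.min-1.g-1 with an expected range from 260 mL.min-1.g-1 to 850 mL.min-1.g-1 in repeated measurements.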

Compound 4, intrinsic clearance in microsomes: 530 mL.min-1.g-1
Beside the measured number, compound 4's estimate is 1.1-fold (0.04 log units) below it; the measured number falls inside the stated range.
By their numbers in this assay, from the lowest: compounds 2, 4, 1 and 3 (each within the scatter of the next).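

In this assay, fluoro in place of hydrogen on an aromatic carbon leaves the number within the scatter (a 1.0-fold lower number from compound 1 to compound 4 (0.01 log units; within the scatter)), and chloro in place of fluoro does the same (a 1.1-fold lower number from compound 3 to compound 4 (0.04 log units; within the scatter)). 2-Chloro-4-fluorophenyl in place of 4-chlorophenyl also stays within it (a 1.8-fold higher number from compound 2 to compound 4 (0.26 log units; within the scatter)), so these four halogen-bearing phenyl groups on the ring nitrogen cannot be told apart here. Nothing available explains this flatness. Still open, as far as these compounds go, is whether a nitrile or a methoxy group in place of the halogens would move the number beyond the scatter.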